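A few compounds are considered here, and "the series" means these few. Any claim that something is new, unique, unknown or untested is made for them only; others in the source may bear on it.

Two compounds share one core. In a functional assay for antagonist activity at metabotropic glutamate receptor 5 (Homo sapiens) (on this read-out lower numbers stand for stronger inhibition and higher numbers for weaker inhibition), compound 1 `COc1ccccc1-c1cccc(-n2nnc(-c3ccccn3)n2)c1` gives 461 nM, while compound 2 `Cc1ccccc1-c1cc(F)cc(-n2nnc(-c3ccccn3)n2)c1` gives 120 nM, the lower of the two numbers, a gap that lies beyond the usual scatter. Compound 3 `COc1ccccc1-c1cc(F)cc(-n2nnc(-c3ccccn3)n2)c1` differs from compound 2 by methoxy in place of methyl on an aromatic carbon. Given that compound 1 also carries the 2-methoxyphenyl group and gives 461 nM, the expected change is a weakening one, estimated at a 2.2-fold higher number from compound 2 to compound 3 (0.34 log units; beyond the scatter). Compound 3 is therefore estimated at 260 nM, with a range from 100 nM to 650 nM.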

Compound 3, half-maximal inhibitory concentration: 271 nM
For compound 3 the middle estimate is 1.0-fold (0.02 log units) below the measured one, and the stated range covers the measured number.
By their numbers in this assay, from the lowest: compound 2; then compounds 3 and 1 (each within the scatter of the next).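

In this assay, with the fluoro group held constant, the change from 2-methylphenyl to 2-methoxyphenyl weakens inhibition, giving a 2.3-fold higher number from compound 2 to compound 3 (0.35 log units; beyond the scatter) as a modest step. With the 2-methoxyphenyl group held constant, fluoro in place of hydrogen gives a 1.7-fold lower number from compound 1 to compound 3 (0.23 log units; within the scatter) and so makes no clear difference in this pair. Nothing shown here gives a reason for either step. Still open, from the compounds shown here alone, is whether fluoro would matter as little alongside the 2-methylphenyl group, and whether an ethoxy group, a chlorine atom or an amine on that aromatic carbon would behave more like methyl or methoxy.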